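Aryl hydrazone nucleoside series: opening binding notes

The compounds below may be only part of what the source reports. "The series", "measured", "known", "first", "only" and "open" are said of these compounds alone.

Compound 1 `Nc1nc(N/N=C/c2ccc(Cl)c(C(F)(F)F)c2)nc2c1ncn2[C@@H]1O[C@H](CO)[C@@H](O)[C@H]1O` stands in an assay on CHO-K1 cells for displacement of a labelled ligand from adenosine receptor A1 (Homo sapiens), read by scintillation counting, with a stated time of 60 min (a higher number here means a weaker inhibitor, a lower number a stronger inhibitor), only at a limit of the assay and not at a number: compound 1 gives > 10000 nM. Compound 2 `Nc1nc(N/N=C/c2ccc(OCc3ccccc3)c(OCc3ccccc3)c2)nc2c1ncn2[C@@H]1O[C@H](CO)[C@@H](O)[C@H]1O` is likewise a limit; in this assay compound 2 gives > 10000 nM. For the measured compounds named here, both values shown sit at the same limit (the limit of > 10000 nM in this assay, at which 2 of the 2 values shown sit), so compound 1 cannot be placed above or below compound 2, and no measured step between the two exists to set the scale of changes.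

Compound 3 `N#Cc1ccccc1/C=N/Nc1nc(N)c2ncn([C@@H]3O[C@H](CO)[C@@H](O)[C@H]3O)c2n1` is not yet measured. It differs from compound 1 by 2-cyanophenyl in place of 4-chloro-3-(trifluoromethyl)phenyl on a carbon with a double bond to nitrogen. With every measured value at the limit, nothing measured points in either direction for this change. The step from compound 1 to compound 3 is therefore expected to be a step that the limit leaves unreadable from compound 1 to compound 3, that is, nothing beyond the scatter, with a further limit as the most likely outcome. For compound 3 the estimate in this assay is 15000 nM, with a range from 3000 nM to 60000 nM.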

Compound 3, inhibition constant: 2.9 nM
Beside the measured number, compound 3's estimate is 5200-fold (3.71 log units) above it; the measured number lies below the stated range.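

In this assay, the group on the carbon with a double bond to nitrogen decides between no readable binding and a measurable number, which neither earlier compound could show. Putting 2-cyanophenyl in place of 4-chloro-3-(trifluoromethyl)phenyl gives an at least 3400-fold lower number from compound 1 to compound 3 (3.53 log units; beyond the scatter), so this position can respond strongly to a change of aryl group, and the shared core does not by itself hold the series at the limit. Compound 3 gives the series its first number, 2.9 nM. The other compounds remain limits of the assay: the limit of > 10000 nM in this assay, at which 2 of the 3 values shown sit.

The change removes the chloro and trifluoromethyl groups and brings in a nitrile in a single step, and the step is bounded on one side only, so the compounds shown cannot assign it to any one of these features or give its full size. From the compounds shown here alone, it also remains open whether the number would hold with a plain phenyl group, or with an amine or a carboxylic acid in place of the nitrile.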